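The source may report more compounds than this note shows. Statements on the series, on what has been measured and on what is new or still open speak of the compounds shown alone.

Compound 1 (`O=C(Nc1ccccc1Cl)C(Cl)Cl`) has no number to start from: in a functional assay on KB cells (Homo sapiens) for antiproliferative activity, read by MTT assay, with a stated time of 72 h (on this read-out higher numbers stand for weaker inhibition and lower numbers for stronger inhibition), compound 1 stands at "not determined" (no result reported). Within the data shown here, the only measured neighbour is compound 2 (`O=C(Nc1ccccc1[N+](=O)[O-])C(Cl)Cl`), and in this assay compound 2 gives 253000 nM. Compound 3 (`O=C(Nc1cccc(Cl)c1Cl)C(Cl)Cl`) differs from compound 1 by one change, (chloro in place of hydrogen on an aromatic carbon), which is chloro in place of hydrogen on an aromatic carbon. Among the measured compounds shown here, no measured step shows what such a change does, so only a modest move toward stronger inhibition is expected in this assay, and its size is uncertain. For compound 3 the estimated value is 150000 nM, with an expected range of 50000 nM to 400000 nM.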

Compound 3, half-maximal inhibitory concentration: 217000 nM
Estimate against measurement, compound 3: 1.4-fold (0.16 log units) below; the measured number falls inside the stated range.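

No step can be read from compound 1 to compound 3: only compound 3 of the pair carries a number. The compounds shown leave open what the added chloro does to activity. No supporting data bear on this result.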